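Bromo to chloro on the fused ring of compound 3

The source may report more compounds than this note shows. Statements on the series, on what has been measured and on what is new or still open speak of the compounds shown alone.

Three compounds of the series have numbers in a functional assay on cells (Cancer cell lines, Homo sapiens) for cytotoxicity, read by sulforhodamine B assay, with a stated time of 48 h; a lower number here means a stronger inhibitor of growth, a higher number a weaker inhibitor of growth. Compound 1 `COc1ccc(C2=NN(C3=NC(=O)/C(=C4\C(=O)Nc5ccc(Cl)cc54)S3)C(c3ccc(Cl)cc3)C2)cc1` gives 740 nM in this assay. Compound 2 `CN(C)c1ccc(C2CC(c3ccccc3)=NN2C2=NC(=O)/C(=C3\C(=O)Nc4ccc(Br)cc43)S2)cc1` gives 720 nM in this assay; the numbers of compound 1 and compound 2 lie within the scatter of each other. Compound 3 `COc1ccc(-c2cc(-c3ccc(Cl)cc3)n(C3C(=O)Nc4ccc(Br)cc43)n2)cc1` gives 22100 nM in this assay, the highest of the three numbers, and its gap to each of the other two lies beyond the scatter. Going by the values given here, compound 3 carries a different core from compound 1 and compound 2, and no single-point step connects it to either of them, so only the bare numbers can be set side by side.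

Compound 4 `COc1ccc(-c2cc(-c3ccc(Cl)cc3)n(C3C(=O)Nc4ccc(Cl)cc43)n2)cc1` is not yet measured. It differs from compound 3 in one place: chloro in place of bromo on an aromatic carbon. Among the compounds with values here, no measured pair shows this exchange at this place. An exchange of one halogen for another of this kind is expected to move the number little, if at all, in this assay; no step beyond the scatter is expected, in either direction. For compound 4 the estimate is a step of a 1.1-fold higher number from compound 3 to compound 4 (0.04 log units; within the scatter). Compound 4 is expected to give about 24000 nM in this assay, with a likely range from 10000 nM to 60000 nM.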

Compound 4, concentration for total growth inhibition: 20300 nM
Estimate against measurement, compound 4: 1.2-fold (0.07 log units) above, and the stated range covers the measured number.
By their numbers in this assay, from the lowest: compounds 2 and 1 (each within the scatter of the next); then compounds 4 and 3 (each within the scatter of the next).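

In this assay, going by these compounds alone, chloro in place of bromo on this aromatic carbon of the fused system gives a 1.1-fold lower number from compound 3 to compound 4 (0.04 log units; within the scatter), and this pair provides the only single-point step, so this position can now be read directly and not only through bare numbers set side by side. On the core of compound 3, the two halogens therefore cannot be told apart at this position, although this rests on one exchange and on one core. No measured property of either halogen, and no other supporting data, bears on this result.

As far as these compounds go, whether this position stays as flat for a group other than a halogen, such as an amine or a carboxylic acid, remains open, as does the effect of a plain hydrogen on this carbon. Also open, from the compounds shown here alone, is whether the same exchange would give a similar step on the core of compound 1 and compound 2, which carry chloro and bromo at this place but also differ from each other elsewhere.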